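The compounds below may be only part of what the source reports. "The series", "measured", "known", "first", "only" and "open" are said of these compounds alone.

Measured compounds:
Compound 1, `O=C(Nc1cccc(-n2cc(-c3ccncc3)c(-c3ccc(Cl)c(O)c3)n2)c1)Nc1cccc(C(F)(F)F)c1`, in a functional assay on UACC-257 cells (Homo sapiens) for inhibition, read by sulforhodamine B assay, with a stated time of 48 h (on this read-out lower numbers stand for higher toxicity in this test and higher numbers for lower toxicity in this test), gives > 32500 nM, which is a limit of the assay and not a number.
Compound 2, `COc1cc(-c2nn(-c3cccc(NC(=O)Nc4ccc(Cl)c(C(F)(F)F)c4)c3)cc2-c2ccncc2)ccc1Cl`, in this assay gives 29200 nM.

Compound 2 thus gives the only number shown; the other value is a limit. Compound 1 sits at the limit of > 32500 nM in this assay, at which 1 of the 2 values shown sits. Compound 3, `O=C(Nc1cccc(-n2cc(-c3ccncc3)c(-c3ccc(Cl)c(O)c3)n2)c1)Nc1ccc(Cl)c(C(F)(F)F)c1`, is not yet measured. It differs from compound 2 by hydrogen in place of methyl on an oxygen on an aromatic ring. For the measured compounds named here, no step between measured compounds is available, so the size of such a change is not known here. The expected step is a 1.0-fold higher number from compound 2 to compound 3 (0.01 log units; within the scatter), hardly beyond the usual scatter. Compound 3 is expected at 30000 nM, within 12000 nM to 70000 nM, and may well come back only as a limit.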

Compound 3, concentration lethal to 50% of the cells: 8390 nM
Estimate against measurement, compound 3: 3.6-fold (0.55 log units) above, and the stated range ends above it.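

In this assay, the change from methoxy to hydroxy gives a 3.5-fold lower number from compound 2 to compound 3 (0.54 log units; beyond the scatter), so this small change on the oxygen shifts the read-out towards higher toxicity in this test. With the hydroxy kept, chloro in place of hydrogen on an aromatic carbon gives an at least 3.8-fold lower number from compound 1 to compound 3 (0.58 log units; beyond the scatter). Compound 1 gives a limit and not a number: the limit of > 32500 nM in this assay, at which 1 of the 3 values shown sits.

As far as these compounds go, it remains open whether an ethoxy group or an amine in place of the hydroxy would move the number further. From the compounds shown here alone, it is also open whether the change from methoxy to hydroxy has the same effect without the chloro.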